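A few compounds are considered here, and "the series" means these few. Any claim that something is new, unique, unknown or untested is made for them only; others in the source may bear on it.

Of the compounds shown here, two with the same core have been measured so far in a functional assay on L1210 cells (Mus musculus) for antiproliferative activity; on this read-out lower numbers stand for stronger inhibition and higher numbers for weaker inhibition. Compound 1 (`COc1cc(C(=O)c2sc(-c3cccc([N+](=O)[O-])c3)cc2N)cc(OC)c1OC`) gives 11 nM there. Compound 2 (`COc1cc(C(=O)c2sc(-c3ccncc3)cc2N)cc(OC)c1OC`) gives 1810 nM as the higher of the two numbers, which makes it the weaker inhibitor of the pair. Compound 3 (`COc1cccc(-c2cc(N)c(C(=O)c3cc(OC)c(OC)c(OC)c3)s2)c1`) has not yet been measured. It carries 3-methoxyphenyl in place of the pyridin-4-yl of compound 2 on an aromatic carbon, next to the ring sulfur (3-methoxyphenyl in place of pyridin-4-yl on an aromatic carbon). Among the compounds with values here, only one measured step bears on this change. Replacing 3-nitrophenyl with pyridin-4-yl at that carbon gave a 160-fold higher number from compound 1 to compound 2 (2.22 log units; beyond the scatter) as a large loss. Within the data shown here, compound 3 returns to a six-membered aromatic ring of carbon only, as in compound 1, but no compound with 3-methoxyphenyl has been measured, so a full return to the number of compound 1 cannot be assumed. A large move to a lower number is therefore expected in this assay, with the estimate being a 20-fold lower number from compound 2 to compound 3 (1.30 log units; beyond the scatter) as the likely step. Compound 3 is estimated at 90 nM with an expected range from 15 nM to 550 nM.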

Compound 3, half-maximal inhibitory concentration: 22 nM
Estimate against measurement, compound 3: 4.1-fold (0.61 log units) above, and the stated range covers the measured number.
By their numbers in this assay, from the lowest: compounds 1 and 3 (each within the scatter of the next); then compound 2.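

In this assay, 3-methoxyphenyl in place of pyridin-4-yl on the aromatic carbon next to the ring sulfur gives a step of large size (an 82-fold lower number from compound 2 to compound 3 (1.92 log units; beyond the scatter)). The earlier loss is therefore recovered with a second ring of carbon only and does not depend on the 3-nitrophenyl of compound 1, and compounds 1 and 3 cannot be told apart in this read-out (a 2.0-fold higher number from compound 1 to compound 3 (0.30 log units; within the scatter)), although methoxy and nitro are quite different groups. Nothing available accounts for either step, so the data show how large the differences are but give no reason for them.

The compounds shown leave open whether an unsubstituted phenyl ring would match compounds 1 and 3, or whether these need a group on the phenyl ring at all, and whether pyridin-3-yl would share the weak number of compound 2. They also leave open how far this carbon tolerates a group such as an amine or a carboxylic acid on the phenyl ring in this assay.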